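Swapping one aromatic group on compound 1

This account rests on a few compounds, and the source may have more. Where it says the series, first, only, none or still open, it means among the compounds named here.

compound 1 `Cn1nccc1-c1cc(C(F)(F)F)ccc1[C@H]1CCOc2cc(S(=O)(=O)Nc3nccs3)ccc21` gives 68%
compound 2 `Cn1nccc1-c1cc(C(F)(F)F)ccc1[C@H]1CCOc2cc(S(=O)(=O)Nc3ncccn3)ccc21` gives 89%
compound 3 `Cn1nccc1-c1cc(C(F)(F)F)ccc1[C@H]1CCc2cc(S(=O)(=O)Nc3ncccn3)ccc21` gives 99%

In an ADME assay on the whole organism (Mus musculus, strain BALB/c) for pharmacokinetics, read by LC-MS, with a stated time of 24 h, at a dose of 10 mg/kg by the oral route (on this read-out lower numbers stand for lower oral bioavailability and higher numbers for higher oral bioavailability), compound 1 stands lowest of these three, and the numbers of both other compounds lie beyond the scatter from it. Compound 4 `O=S(=O)(Nc1nccs1)c1ccc2c(c1)OCC[C@@H]2c1ccc(C(F)(F)F)cc1-c1ccc(F)nc1` keeps the core of compound 1 and its sulfonamide but carries 6-fluoropyridin-3-yl in place of 1-methyl-1H-pyrazol-5-yl on an aromatic carbon . Going by the values given here, no measured pair of compounds changes this group. Among the compounds with values here, the only measured step, a number 21 percentage points higher from compound 1 to compound 2 (beyond the scatter), lies at the sulfonamide nitrogen, so it bears only indirectly: it shows that exchanging one group can move this assay by a modest amount. Its direction cannot be carried over to a different place, so no step beyond the scatter is the best expectation, with real uncertainty either way. The estimated change is a number 6 percentage points lower from compound 1 to compound 4 (within the scatter) and that estimate is loose. Compound 4 is expected to give 62%, with an estimated range from 35% to 85% as its likely span.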

Compound 4, oral bioavailability: 95%
Compound 4: the middle estimate sits 33 percentage points below what was measured; the measured number lies above the stated range.
By their numbers in this assay, from the lowest: compound 1; then compounds 2, 4 and 3 (each within the scatter of the next).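

The aromatic carbon ortho to a large group and meta to the trifluoromethyl group turns out to matter: in this assay, 6-fluoropyridin-3-yl in place of 1-methyl-1H-pyrazol-5-yl gives a number 27 percentage points higher from compound 1 to compound 4 (beyond the scatter). So a change at this position, and not only the one at the sulfonamide nitrogen, can shift this read-out beyond the scatter, here with the 1,3-thiazol-2-yl sulfonamide left as it is. No measurement shown explains this rise.

With a single replacement at this position, the ring size, the ring nitrogen and the fluorine cannot be told apart, and a plain phenyl ring or an unsubstituted pyridin-3-yl would be the next groups to compare. Also open, going by these compounds, is whether 6-fluoropyridin-3-yl has a similar effect when the sulfonamide carries pyrimidin-2-yl.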